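The source may hold more compounds than are shown below. What is called first, only, known or untested is meant among the compounds shown, and "the series" means these compounds.

Measured compounds:
compound 1, `N=C(N)NCCC[C@H](NC(=O)CN(c1ncnc2c1ncn2C1CCCCO1)C1CC1)C(=O)OCc1ccccc1`, 19.6%
compound 2, `N=C(N)NCCC[C@H](NC(=O)CN(c1nc(Cl)nc2[nH]cnc12)C1CC1)C(=O)OCc1ccccc1`, 6.12%
compound 3, `O=C(CN(c1nc(Cl)nc2[nH]cnc12)C1CC1)N[C@@H](CC(=O)OCc1ccccc1)C(=O)OCc1ccccc1`, 6.68%

In a functional assay on the whole organism (Tail, strain ICR) with Mus musculus as the target, in the tail flick test, with a stated time of 150 min, at a dose of 25 umol/kg by the oral route (a lower number here means a weaker effect, a higher number a stronger effect of the compound at the dose given), compound 1 gives the highest of the three numbers; compound 3 lies below it by a gap beyond the scatter, and compound 2 lies furthest below, also beyond the scatter. Compound 4, `C[C@H](NC(=O)CN(c1ncnc2c1ncn2C1CCCCO1)C1CC1)C(=O)OCc1ccccc1`, has not yet been tested in this assay. It differs from compound 1 in one place: a hydrogen atom in place of a group of 6 heavy atoms (3 carbon, 3 nitrogen; no ring), on a saturated chain carbon, two bonds along the chain from an amide-type nitrogen and a carbonyl carbon. Among the measured compounds shown here, only one measured step touches the same position. It is a number 0.6 percentage points higher from compound 2 to compound 3 (within the scatter), in which the group of 6 heavy atoms (3 carbon, 3 nitrogen; no ring) was exchanged for a group of 10 heavy atoms on the shared core of compounds 2 and 3, and the number did not move beyond the scatter. That step, however, sits on a different core and on different partners, and neither of those compounds reaches the number of compound 1. It is therefore expected that removing the group in compound 4 yields a step of a number 7.6 percentage points lower from compound 1 to compound 4 (within the scatter) that is small and more likely downward than upward. Compound 4 is estimated at 12%, with a range from 2% to 24%.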

Compound 4, a percentage reported as activity, at one dose (the size of the read-out at that dose, not a potency): 6.01%
For compound 4 the middle estimate is 6 percentage points above the measured one; the measured number falls inside the stated range.
By their numbers in this assay, from the lowest: compounds 4, 2 and 3 (each within the scatter of the next); then compound 1.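

In this assay, replacing the group of 6 heavy atoms (3 carbon, 3 nitrogen; no ring) with a hydrogen atom gives a number 13.6 percentage points lower from compound 1 to compound 4 (beyond the scatter) and so shows that, on this core, the change at this saturated chain carbon registers beyond the scatter. The earlier step at the same place, a number 0.6 percentage points higher from compound 2 to compound 3 (within the scatter) on a different core, exchanged that group for a group of 10 heavy atoms and could not show what happens when the group is simply lost. No measurement at hand gives a reason for the new step.

On these data alone, whether an amine, a carboxylic acid or a longer chain at this place would hold the number of compound 1 remains open. As far as these compounds go, it is also open whether a hydrogen atom here would give a comparable step on the core of compound 2.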